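A few compounds are considered here, and "the series" means these few. Any claim that something is new, unique, unknown or untested is made for them only; others in the source may bear on it.

Measured in a functional assay on A549 cells (Homo sapiens) for inhibition, read by MTT assay, with a stated time of 48 h; a lower number here means a stronger inhibitor, a higher number a weaker inhibitor:
- compound 1 `COc1ccc(/C=C/c2cc(OC)cc(OC)c2/C=C/C(=O)N2CCC(Cl)CC2)cc1` — 2080 nM
- compound 2 `COc1ccc(/C=C/c2cc(OC)cc(OC)c2/C=C/C(=O)N2CCCC2)cc1` — 6350 nM

For the measured compounds named here, compound 2 stands at the higher of the two numbers; the single measured step is a 3.1-fold higher number from compound 1 to compound 2 (0.48 log units; beyond the scatter). Compound 3 `COc1ccc(/C=C/c2cc(OC)cc(OC)c2/C=C/C(=O)N2CCC(c3ccccc3)CC2)cc1` differs from compound 2 by 4-phenylpiperidin-1-yl in place of pyrrolidin-1-yl on a carbonyl carbon. Going by the values given here, only the step from compound 1 to compound 2 bears on this change, and it points the other way: the six-membered ring carrying a substituent gave the lower number. A step back toward that, a 4.2-fold lower number from compound 2 to compound 3 (0.63 log units; beyond the scatter), is expected in this assay. Compound 3 is therefore estimated at 1500 nM, with a range of 500 nM to 5000 nM; the substituent differs from that of compound 1, so the range is kept wide.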

Compound 3, half-maximal inhibitory concentration: 6690 nM
Beside the measured number, compound 3's estimate is 4.5-fold (0.65 log units) below it; measured number outside the range, above it.
By their numbers in this assay, from the lowest: compound 1; then compounds 2 and 3 (each within the scatter of the next).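

In this assay, a phenyl on the piperidine ring does not retain the lower number of compound 1 (a 3.2-fold higher number from compound 1 to compound 3 (0.51 log units; beyond the scatter)), so a substituted six-membered ring alone does not give that number. 4-Phenylpiperidin-1-yl and pyrrolidin-1-yl are not separated on the carbonyl carbon (a 1.1-fold higher number from compound 2 to compound 3 (0.02 log units; within the scatter)), despite the added ring. No evidence accompanies these results to explain them.

Open, from the compounds shown here alone, is whether the lower number is specific to chloro or is shared by fluoro, methyl or hydroxyl on the same ring carbon. Also open, going by these compounds, is how a morpholin-4-yl group would read on the carbonyl carbon.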